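A few compounds are considered here, and "the series" means these few. Any claim that something is new, unique, unknown or untested is made for them only; others in the source may bear on it.

Measured in a functional assay on MGC-803 cells (Homo sapiens) for cytotoxicity, read by MTT assay, with a stated time of 48 h; a higher number here means a weaker inhibitor, a lower number a stronger inhibitor:

- compound 1 `CCC(=O)N1N=C(C)CC1c1cc(Br)ccc1O` gives 50300 nM
- compound 2 `CCN(CC)CC(=O)N1N=C(C)CC1c1ccccc1O` gives 39800 nM
- compound 3 `CCN(CC)CC(=O)N1N=C(C)CC1c1ccccc1OC(C)=O` gives 29500 nM

Compound 3, at 29500 nM, lies within the scatter of both compound 1 and compound 2, so none of the three stands apart in this assay.

Compound 4 `CC(=O)Oc1ccccc1C1CC(C)=NN1C(=O)CN1CCC(C(C)=O)CC1` has 4-acetylpiperidin-1-yl in place of diethylamino on a saturated chain carbon bound to a carbonyl carbon.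

Only one measured step connects two of these compounds, a 1.3-fold lower number from compound 2 to compound 3 (0.13 log units; within the scatter). Among the measured compounds shown here, it concerns acetyl in place of hydrogen on an oxygen on an aromatic ring, and no measured step replaces diethylamino. The data therefore give no direction for this change, and no shift beyond the scatter is expected, although the uncertainty is wide. The estimate means a 1.2-fold lower number from compound 3 to compound 4 (0.07 log units; within the scatter). The estimated value for compound 4 is 25000 nM, with an expected range from 8000 nM to 70000 nM.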

Compound 4, half-maximal inhibitory concentration: 4120 nM
Beside the measured number, compound 4's estimate is 6.1-fold (0.78 log units) above it; the measured number lies below the stated range.
By their numbers in this assay, from the lowest: compound 4; then compounds 3, 2 and 1 (each within the scatter of the next).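

In this assay, among the compounds shown here, replacing diethylamino with 4-acetylpiperidin-1-yl on a saturated chain carbon bound to a carbonyl carbon gives a 7.2-fold lower number from compound 3 to compound 4 (0.85 log units; beyond the scatter) and is the only step here beyond the scatter, so this position responds to the choice of group in a way the acetyl change on the aromatic oxygen did not show. The change brings in a six-membered non-aromatic ring and an acetyl group together, and this single step cannot separate the two. Nothing available accounts for the size of the step.

Plain piperidin-1-yl, or a piperidine carrying a carboxylic acid in place of the acetyl, would be needed to tell the ring from its acetyl group. Going by these compounds, it also remains open whether 4-acetylpiperidin-1-yl would act alike on compound 2, which keeps hydrogen on the aromatic oxygen.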